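Methyl on the Phenyl Ring: A Step Expected Within Scatter

The source may hold more compounds than are shown below. What is called first, only, known or untested is meant among the compounds shown, and "the series" means these compounds.

Measured compounds:
Compound 1, `CCOc1nc(-c2cc3ccccc3o2)cc(-c2ccccc2)c1C#N`, gives 310000 nM in a functional assay on aorta (strain Wistar) for inhibition, with Thoracic aorta (Rattus norvegicus) as the target; a higher number here means a weaker inhibitor, a lower number a stronger inhibitor.
Compound 2, `COc1nc(-c2cc3ccccc3o2)cc(-c2ccc(Br)cc2)c1C#N`, gives 298000 nM in this assay .

Among the measured compounds shown here, compound 1 is one of only two measured compounds, and its number in this assay lies within the usual scatter of the number for compound 2, so the two measurements cannot be told apart. Both compounds inhibit only at very high concentration, and nothing in these two values separates them.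

Compound 3, `CCOc1nc(-c2cc3ccccc3o2)cc(-c2ccc(C)cc2)c1C#N`, differs from compound 1 by methyl in place of hydrogen on an aromatic carbon. For the measured compounds named here, no measured pair shows this change in this assay, so its effect is not known from the data at hand. Going by the values given here, because compound 2 gives 298000 nM, a value that falls within the scatter of compound 1, the only comparison available suggests that a small change on this ring moves the number little. Compound 3 is therefore expected to show a step of a 1.0-fold lower number from compound 1 to compound 3 (0.01 log units; within the scatter) that stays within the scatter, in no particular direction. Compound 3 is estimated to give 300000 nM, with a range from 150000 nM to 600000 nM.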

Compound 3, half-maximal inhibitory concentration: 290000 nM
Beside the measured number, compound 3's estimate is 1.0-fold (0.01 log units) above it; measured number inside the range.
By their numbers in this assay, from the lowest: compounds 3, 2 and 1 (each within the scatter of the next).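

Among the compounds shown here, putting methyl in place of hydrogen on this aromatic carbon, para to a large group, gives the first single-change step in this assay, with a 1.1-fold lower number from compound 1 to compound 3 (0.03 log units; within the scatter) lying within the scatter. Where the earlier compounds differed in more than one place, this pair isolates the change from phenyl to 4-methylphenyl, and compound 1 and compound 3 cannot be told apart, so this position accepts a methyl without a difference that this measurement can detect. Nothing at hand accounts for this result or gives any measured property of the methyl group.

As far as these compounds go, it remains open whether any other group at this position, such as an amine, a carboxylic acid or a longer chain, would give a number beyond the scatter, since a single methyl step cannot show how far this tolerance extends. For the compounds shown here, it also remains open whether a change elsewhere on the shared core, taken on its own, would move the number at all, as no such single-change pair is available here.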